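The compounds below may be only part of what the source reports. "The series", "measured", "known", "first", "only" and "open" are said of these compounds alone.

Working notes on the series. In a functional assay on HL-60 cells (Homo sapiens) for antiproliferative activity, read by MTT assay, with a stated time of 48 h (on this read-out higher numbers stand for weaker inhibition and lower numbers for stronger inhibition), compound 1 (`CC(C)=CCC[C@]1(C)/C=C/[C@@H](OC(=O)C=C(C)C)[C@](C)(O)/C=C/C(=O)/C(CN2CCN(C)CC2)=C\C1`) gives 840 nM. Going by the values given here, in the same read-out, compound 2 (`CC(C)=CCC[C@]1(C)/C=C/[C@@H](OC(=O)C=C(C)C)[C@](C)(O)/C=C/C(=O)/C(C(=O)N(C)C)=C\C1`) gives 3340 nM, the higher of the only two numbers so far and so the weaker inhibition of the pair. Among the compounds with values here, the one measured step is a 4.0-fold higher number from compound 1 to compound 2 (0.60 log units; beyond the scatter), modest but beyond the scatter, with dimethylcarbamoyl in place of (4-methylpiperazin-1-yl)methyl on a double-bonded ring carbon.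

Compound 3 (`CCN(CC)C(=O)/C1=C/C[C@](C)(CCC=C(C)C)/C=C/[C@@H](OC(=O)C=C(C)C)[C@](C)(O)/C=C/C1=O`) differs from compound 2 only at the amide: diethylamino in place of dimethylamino on a carbonyl carbon. In short, this is diethylamino in place of dimethylamino on a carbonyl carbon, or dimethylcarbamoyl to diethylcarbamoyl.

The measured step bears on this only loosely, since it exchanges the whole group, while here the carbonyl stays in place. Within the data shown here, no measured pair tests a change within the amino part, so its direction is unknown. No step beyond the scatter is expected in this assay, and the estimate is anchored on compound 2 at 3340 nM, with a wide range. The expected step is a 1.1-fold lower number from compound 2 to compound 3 (0.05 log units; within the scatter). For compound 3 the estimated value is 3000 nM, with an expected range of 1300 nM to 7000 nM.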

Compound 3, half-maximal inhibitory concentration: 9080 nM
Estimate against measurement, compound 3: 3.0-fold (0.48 log units) below; the measured number lies above the stated range.
By their numbers in this assay, from the lowest: compound 1; then compound 2; then compound 3.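

In this assay, the amino part of the amide proves to be a place that matters: with the carbonyl kept, diethylamino in place of dimethylamino on a carbonyl carbon gives a 2.7-fold higher number from compound 2 to compound 3 (0.43 log units; beyond the scatter). Replacing (4-methylpiperazin-1-yl)methyl with diethylcarbamoyl on a double-bonded ring carbon gives an 11-fold higher number from compound 1 to compound 3 (1.03 log units; beyond the scatter), so both amides carry higher numbers than compound 1, and the diethylamino amide carries the highest; none of the three compounds goes against this order, though three compounds are a narrow base for it. Nothing measured here accounts for these steps.

On these data alone, it remains open whether the number keeps rising with a longer chain on the amide nitrogen, as in dipropylamino, or whether a cyclic amine such as pyrrolidin-1-yl or morpholin-4-yl on the same carbonyl carbon follows diethylamino or dimethylamino. Also open, as far as these compounds go, is where a 4-methylpiperazine-1-carbonyl group would fall, since that amide would keep the amine of compound 1 while carrying the carbonyl of compound 2 and compound 3, and so would separate the two parts of the exchange.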